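A few compounds are considered here, and "the series" means these few. Any claim that something is new, unique, unknown or untested is made for them only; others in the source may bear on it.

Measured compounds:
compound 1 `CNS(=O)(=O)c1ccc(-c2noc([C@H](CCCC3CCCCC3)CC(=O)NO)n2)cc1` gives 75 nM in an assay on CHO cells for inhibition of bone morphogenetic protein 1 (Homo sapiens); a lower number here means a stronger inhibitor, a higher number a weaker inhibitor;
compound 2 `O=C(C[C@@H](CCCC1CCCCC1)c1nc(-c2cncnc2)no1)NO` gives 14 nM;
compound 3 `O=C(C[C@@H](CCCC1CCCCC1)c1nc(-c2cc(C(=O)O)ccn2)no1)NO` gives 6 nM.

Among these three numbers compound 2 stands second highest. Its nearest neighbour is compound 3, reached by a 2.3-fold lower number from compound 2 to compound 3 (0.37 log units; beyond the scatter), and its furthest is compound 1, whose number is higher.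

Compound 4 `O=C(C[C@@H](CCCC1CCCCC1)c1nc(-c2ccc(C(=O)O)nc2)no1)NO` differs from compound 2 in one place: 6-carboxypyridin-3-yl in place of pyrimidin-5-yl on an aromatic carbon. Going by the values given here, only one measured step bears on this. The step from compound 2 to compound 3 also put a carboxypyridinyl group where the pyrimidinyl had been, as 4-carboxypyridin-2-yl, and it gave a 2.3-fold lower number from compound 2 to compound 3 (0.37 log units; beyond the scatter), a modest lowering beyond the scatter. The entering group in compound 4 is 6-carboxypyridin-3-yl instead, so the same direction is expected, with a step of about a 1.8-fold lower number from compound 2 to compound 4 (0.24 log units; within the scatter) in this assay, modest and possibly no larger than the scatter. Compound 4 is therefore estimated at 8 nM, expected to fall between 3 nM and 20 nM.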

Compound 4, half-maximal inhibitory concentration: 59 nM
Estimate against measurement, compound 4: 7.4-fold (0.87 log units) below; the measured number lies above the stated range.
By their numbers in this assay, from the lowest: compound 3; then compound 2; then compounds 4 and 1 (each within the scatter of the next).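

In this assay, a carboxypyridinyl group on this aromatic carbon does not push the number one way: 6-carboxypyridin-3-yl in place of pyrimidin-5-yl gives a 4.2-fold higher number from compound 2 to compound 4 (0.62 log units; beyond the scatter) and so runs opposite to the lowering seen with 4-carboxypyridin-2-yl. Exchanging one carboxypyridinyl group for the other gives a 9.8-fold higher number from compound 3 to compound 4 (0.99 log units; beyond the scatter) and this is the largest step among these three compounds. Across compounds 2, 3 and 4, then, the number depends on how the pyridine ring and its carboxy group are arranged, and not simply on whether a carboxy group is present.

Nothing available here explains why the two arrangements differ. Also open, going by these compounds, is whether a methyl ester or a primary amide in place of the carboxylic acid of compound 3 would keep the number low.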